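Changing the aryl group on the amide nitrogen of a shared core

This account rests on a few compounds, and the source may have more. Where it says the series, first, only, none or still open, it means among the compounds named here.

Compound 1, `Cc1ccc(F)cc1NC(=O)CN1CCN(c2nnc(Cc3ccccc3)c3ccccc23)CC1`, gives 171000 nM in a functional assay on HT-29 cells (Homo sapiens) for cytotoxicity, read by MTT assay, with a stated time of 72 h; on this read-out lower numbers stand for stronger inhibition and higher numbers for weaker inhibition.
Compound 2, `COc1ccc(NC(=O)CN2CCN(c3nnc(Cc4ccccc4)c4ccccc34)CC2)cc1OC`, gives 145000 nM in this assay.
Compound 3, `Cc1ccccc1NC(=O)CN1CCN(c2nnc(Cc3ccccc3)c3ccccc23)CC1`, gives 113000 nM in this assay.

All three compounds share a core and differ only in the aryl group on the amide nitrogen. Compound 3 has the lowest number of the three, but its steps to the others are small: a 1.3-fold lower number from compound 2 to compound 3 (0.11 log units; within the scatter) and a 1.5-fold lower number from compound 1 to compound 3 (0.18 log units; within the scatter), so no order among them can be claimed.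

Compound 4, `O=C(CN1CCN(c2nnc(Cc3ccccc3)c3ccccc23)CC1)Nc1cc(C(F)(F)F)ccc1Cl`, continues this series with 2-chloro-5-(trifluoromethyl)phenyl in place of 2-methylphenyl on an amide-type nitrogen.

Two earlier swaps of the aryl group on the amide nitrogen bear on this change, a 1.2-fold lower number from compound 1 to compound 2 (0.07 log units; within the scatter) and a 1.3-fold lower number from compound 2 to compound 3 (0.11 log units; within the scatter), and one swap of a halogen on the ring, a 1.5-fold lower number from compound 1 to compound 3 (0.18 log units; within the scatter); none moved the number beyond the scatter. A step of similar size is therefore expected here, with no clear direction: a 1.1-fold higher number from compound 3 to compound 4 (0.03 log units; within the scatter). Compound 4 is estimated at 120000 nM in this assay, expected to lie between 50000 nM and 280000 nM.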

Compound 4, half-maximal inhibitory concentration: 66800 nM
The estimate for compound 4 lay 1.8-fold (0.25 log units) above the measured number; measured number inside the range.
By their numbers in this assay, from the lowest: compounds 4, 3, 2 and 1 (each within the scatter of the next, the first and the last beyond it).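

Placing 2-chloro-5-(trifluoromethyl)phenyl on the amide nitrogen gives the first steps at this position that lie beyond the scatter in this assay: a 2.2-fold lower number from compound 2 to compound 4 (0.34 log units; beyond the scatter) and a 2.6-fold lower number from compound 1 to compound 4 (0.41 log units; beyond the scatter), both modest. The step from the closest comparison stays within the scatter, a 1.7-fold lower number from compound 3 to compound 4 (0.23 log units; within the scatter), so compound 3 and compound 4 cannot be told apart, and the position shows only a small spread so far. Nothing available here explains the shift seen with this group.

On these data alone, it remains open whether a phenyl ring carrying only the chloro group or only the trifluoromethyl group would give the same steps, so the contribution of each cannot be separated. Also open, as far as these compounds go, is how the number would respond to a non-aromatic group such as cyclohexyl, or to a phenyl ring bearing a carboxylic acid or an amine.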